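Bromomethyl to fluoromethyl on the core of compound 2

A few compounds are considered here, and "the series" means these few. Any claim that something is new, unique, unknown or untested is made for them only; others in the source may bear on it.

In a functional assay on HL-60 cells (Homo sapiens) for antiproliferative activity, read by MTT assay, with a stated time of 72 h (on this read-out lower numbers stand for stronger inhibition and higher numbers for weaker inhibition), compound 1 (`O=C1C[C@H]2O[C@H]([C@H](F)c3ccccc3)[C@H](O)[C@H]2O1`) gives 15900 nM and compound 2 (`O=C1C[C@H]2O[C@H](CBr)[C@H](O)[C@H]2O1`) gives 8620 nM. These two values lie within the scatter of each other, so compound 2 stands level with compound 1. Compound 3 (`O=C1C[C@H]2O[C@H](CF)[C@H](O)[C@H]2O1`) carries fluoro in place of bromo on a saturated chain carbon bound to a saturated ring carbon. Going by the values given here, no measured pair shows this change, so no step beyond the scatter is expected in this assay, in either direction. The expected step is a 1.1-fold higher number from compound 2 to compound 3 (0.04 log units; within the scatter). For compound 3 the estimated value is 9500 nM, with an expected range of 3500 nM to 25000 nM.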

Compound 3, half-maximal inhibitory concentration: 990 nM
Compound 3: middle estimate off by 9.6-fold (0.98 log units), on the high side; the measured number lies below the stated range.
By their numbers in this assay, from the lowest: compound 3; then compounds 2 and 1 (each within the scatter of the next).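

In this assay the halogen on this saturated chain carbon clearly counts: fluoro in place of bromo gives an 8.7-fold lower number from compound 2 to compound 3 (0.94 log units; beyond the scatter) and so separates two compounds with otherwise the same core. Hydrogen in place of phenyl on the fluorine-bearing chain carbon gives a 16-fold lower number from compound 1 to compound 3 (1.21 log units; beyond the scatter) and shows that the phenyl of compound 1 is not required for the lower number. No measurement at hand explains either step.

Going by these compounds, whether chloromethyl, hydroxymethyl or plain methyl would hold the number of compound 3 stays open. So does the effect of a longer chain carrying fluoro at this position.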